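A few compounds are considered here, and "the series" means these few. Any claim that something is new, unique, unknown or untested is made for them only; others in the source may bear on it.

Among the compounds measured in a functional assay on HT-29 cells (Homo sapiens) for inhibition, read by sulforhodamine B assay, with a stated time of 72 h (on this read-out higher numbers stand for weaker inhibition and lower numbers for stronger inhibition), compound 1 `C=CC1C(=O)N(c2cc(OC)c(OC)c(OC)c2)C1c1ccc(OC)cc1` gives the lowest number, 10 nM. Compound 2 `COc1ccc(C2C(C3CC3)C(=O)N2c2cc(OC)c(OC)c(OC)c2)cc1` gives 107 nM, and compound 3 `COc1ccc(C2CC(=O)N2c2cc(OC)c(OC)c(OC)c2)cc1O` gives 521 nM. For the measured compounds named here, the only step measured in one place, an 11-fold higher number from compound 1 to compound 2 (1.03 log units; beyond the scatter), is a change at a saturated ring carbon, and between compound 1 and compound 3 two things differ, so only their values can be compared.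

Compound 4 `C=CC1C(=O)N(c2cc(OC)c(OC)c(OC)c2)C1c1ccc(SC)cc1` differs from compound 1 in a single place: methylsulfanyl in place of methoxy on an aromatic carbon. Going by the values given here, no measured step touches this position, so there is no direct guide. Swapping these two groups of equal size is expected to change this assay by little, and compound 4 is therefore expected to give 25 nM, between 5 nM and 120 nM, a step of a 2.5-fold higher number from compound 1 to compound 4 (0.40 log units; beyond the scatter).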

Compound 4, half-maximal inhibitory concentration: 113 nM
The estimate for compound 4 lay 4.5-fold (0.66 log units) below the measured number, and the stated range covers the measured number.
By their numbers in this assay, from the lowest: compound 1; then compounds 2 and 4 (each within the scatter of the next); then compound 3.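

In this assay, for the compounds shown here, the para group on the aromatic ring, which no earlier step touched, turns out to matter: methylsulfanyl in place of methoxy gives an 11-fold higher number from compound 1 to compound 4 (1.05 log units; beyond the scatter) and so weakens inhibition. The two groups have the same heavy-atom count and differ only in sulfur for oxygen, yet this position does not tolerate the exchange. No measurement here explains the loss. Going by these compounds, how an ethoxy group, an amine or a chlorine atom would fare at this position remains open, as does whether methylsulfanyl would have the same effect with cyclopropyl in place of vinyl.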